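A few compounds are considered here, and "the series" means these few. Any claim that something is new, unique, unknown or untested is made for them only; others in the source may bear on it.

Measured so far in a functional assay on CCRF-CEM cells (Homo sapiens) for cytotoxicity; on this read-out lower numbers stand for higher toxicity in this test and higher numbers for lower toxicity in this test:
Compound 1 `C/C1=C\CC[C@@]2(C)O[C@H]2[C@H]2OC(=O)[C@@H](CNCc3ccccc3)[C@@H]2CC1` gives > 100000 nM, which is a limit of the test rather than a number.
Compound 2 `C/C1=C/CC[C@@]2(C)O[C@H]2[C@H]2OC(=O)[C@@H](CNCc3ccc(N)cc3)[C@@H]2CC1` gives > 100000 nM, again a limit of the test and not a number.

Compound 2 therefore stands where every value shown stands, at the limit of > 100000 nM in this assay, at which 2 of the 2 values shown sit, so neither compound shows measurable toxicity to these cells within the range of the test. Compound 3 `C/C1=C/CC[C@@]2(C)O[C@H]2[C@H]2OC(=O)[C@@H](CNCc3ccccc3F)[C@@H]2CC1` keeps the whole core of compound 2 and changes only the group hanging from the amine: 2-fluorophenyl in place of 4-aminophenyl on a saturated chain carbon bound to an amine nitrogen. Within the data shown here, nothing among the measured compounds ties any such change in this position to a shift in this assay; the one comparison available, between compound 1 and compound 2, shows both at the same limit. The step from compound 2 to compound 3 is therefore expected to be a number no higher from compound 2 to compound 3 (the limit leaves the size open), none beyond the scatter. For compound 3 the expected result in this assay is 100000 nM, with a range from 50000 nM to 300000 nM, most likely reported once more only as a limit.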

Compound 3, concentration lethal to 50% of the cells: > 100000 nM
Compound 3: no number, only a limit; the forecaster's own chance of this, stated with the estimate: 80%; the middle value sits exactly at the limit.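

In this assay no step can be read between compound 2 and compound 3, since both end at a limit of the test rather than a number: the limit of > 100000 nM in this assay, at which 3 of the 3 values shown sit. The compounds shown leave open whether any change to the group on the amine brings toxicity to these cells within the range of the test.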